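A few compounds are considered here, and "the series" means these few. Any claim that something is new, unique, unknown or untested is made for them only; others in the source may bear on it.

Among the measured compounds shown here, only two compounds have a number so far in an ADME assay on MRC5 cells (Homo sapiens) for inhibition, with a stated time of 72 h; on this read-out lower numbers stand for an effect already at smaller amounts and higher numbers for an effect only at larger amounts of compound. Compound 1 `CCc1ccccc1C(=O)Nc1c[nH]nc1C(=O)N[C@H]1CC[C@H](OC)CC1` gives 3400 nM, the lower of the two. Compound 2 `COc1cccc(OC)c1C(=O)Nc1c[nH]nc1C(=O)NC1CCN(Cc2ccccc2)C1` gives 38000 nM, and the gap between them lies beyond the usual scatter.

Compound 3 `CO[C@H]1CC[C@H](NC(=O)c2n[nH]cc2NC(=O)c2ccccc2)CC1` has yet to be measured in this assay. It departs from compound 1 at a single place: hydrogen in place of ethyl on an aromatic carbon. This puts hydrogen in place of ethyl on an aromatic carbon, ortho to a large group, so that 2-ethylphenyl becomes phenyl.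

For the measured compounds named here, no measured pair of compounds shows this change on its own, which leaves no direct precedent for its size. A moderate move towards a higher number in this assay is expected, although a result within the scatter would be no surprise. The expectation starts from compound 1 at 3400 nM, and the number expected stays well under that of compound 2, which gives 38000 nM. The expected move is a 2.2-fold higher number from compound 1 to compound 3 (0.34 log units; beyond the scatter). For compound 3 the estimated value is 7500 nM, with an expected range from 2500 nM to 25000 nM.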

Compound 3, half-maximal effective concentration: 800 nM
Compound 3: the middle estimate sits 9.4-fold (0.97 log units) above what was measured; the whole stated range lies above it.
By their numbers in this assay, from the lowest: compound 3; then compound 1; then compound 2.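

In this assay, taking away the ethyl group gives a 4.3-fold lower number from compound 1 to compound 3 (0.63 log units; beyond the scatter), and this first single-place step shows that the ethyl group, ortho to a large group on the six-membered aromatic ring, is not required for a low number on this read-out. The plain phenyl of compound 3 in fact does better than the 2-ethylphenyl of compound 1, with a step that lies beyond the scatter, although the change removes only two carbon atoms and no hydrogen-bond donor, hydrogen-bond acceptor or charge. No measurement shown here bears on why the number moves in this direction.

The compounds shown leave open whether a methyl group, a chlorine atom or an amine at this same place would keep the number as low as hydrogen does, and whether a chain longer than ethyl would carry it further the other way. From the compounds shown here alone, this reading also rests on one step against one set of surroundings, so it remains open whether replacing ethyl with hydrogen does the same when the rest of compound 1 is different.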